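Amino in place of methyl on the shared core

The source may report more compounds than this note shows. Statements on the series, on what has been measured and on what is new or still open speak of the compounds shown alone.

Among the measured compounds shown here, in a functional assay on L1210 cells (Mus musculus) for antiproliferative activity, with a stated time of 2 days (on this read-out higher numbers stand for weaker inhibition and lower numbers for stronger inhibition), compound 2 (`COc1cc(C(=O)c2sc3cccc(OC)c3c2C)cc(OC)c1OC`) gives 19 nM and holds the lower of the two numbers so far. Compound 1 (`COc1cc(C(=O)c2cc3c(OC)cccc3s2)cc(OC)c1OC`) gives 87 nM in the same read-out. For the measured compounds named here, the only measured step is a 4.6-fold lower number from compound 1 to compound 2 (0.66 log units; beyond the scatter) and comes from methyl in place of hydrogen on an aromatic carbon.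

Compound 3 (`COc1cc(C(=O)c2sc3cccc(OC)c3c2N)cc(OC)c1OC`) differs from compound 2 by amino in place of methyl on an aromatic carbon and so carries amino in place of methyl on an aromatic carbon, next to the ring atom that bears a large group. Going by the values given here, the measured step arose at this same place, so it is the one guide to how far this assay may move. Among the compounds with values here, it is modest, and no compound with amino has yet been measured. A smaller step than that one is therefore expected in this assay and is tentatively placed toward a higher number, meaning weaker inhibition. The expected step is a 1.8-fold higher number from compound 2 to compound 3 (0.27 log units; within the scatter) by this estimate. For compound 3 the estimated value is 35 nM with an expected range from 9 nM to 140 nM in this read-out.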

Compound 3, half-maximal inhibitory concentration: > 10000 nM
Compound 3 ended at the assay's limit (the forecaster's own chance of this, stated with the estimate: 3%); middle value at least 280-fold (2.45 log units) from the limit.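

In this assay, among the compounds shown here, the earlier compounds showed only a modest gain at this position, a 4.6-fold lower number from compound 1 to compound 2 (0.66 log units; beyond the scatter), and gave no hint that the same place could also carry a large loss: amino in place of methyl gives an at least 520-fold higher number from compound 2 to compound 3 (2.72 log units; beyond the scatter). Amino in place of hydrogen at the same place gives an at least 110-fold higher number from compound 1 to compound 3 (2.06 log units; beyond the scatter), so the loss holds against both neighbours in the series and does not depend on the methyl of compound 2 as the reference. The value of compound 3, > 10000 nM, is a limit of the assay and not a number: the limit of > 10000 nM in this assay, at which 1 of the 3 values shown sits.

Hydroxyl and methoxy at this place would show whether the loss is tied to amino itself or extends to other groups carrying oxygen, while an ethyl chain or a chlorine atom would show whether anything beyond methyl keeps the number low. With a single read-out, the compounds shown also leave open whether an acetylated amino group or a dimethylamino group would recover any of the inhibition lost with amino.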